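Second methyl on the core of compound 3

The source may report more compounds than this note shows. Statements on the series, on what has been measured and on what is new or still open speak of the compounds shown alone.

In a functional assay on MDA-MB-435 cells (Homo sapiens) for antiproliferative activity (on this read-out higher numbers stand for weaker inhibition of growth and lower numbers for stronger inhibition of growth), compound 3 `Cc1ccnc2nc(-c3cccc(Cl)c3)cc(O)c12` gives only a limit, < 10 nM. Compound 1 `Cc1ccc2c(O)cc(-c3cccc(Cl)c3)nc2n1` likewise gives only a limit in this assay, < 10 nM. Together they define (the limit of < 10 nM in this assay, at which 2 of the 3 values shown sit). Compound 2 `Cc1cccc(-c2cc(O)c3c(C)cc(C)nc3n2)c1`, carrying two methyl groups on its core and a methylphenyl aryl, gives 20000 nM in this assay. Compound 4 `Cc1cc(C)c2c(O)cc(-c3cccc(Cl)c3)nc2n1` arises from compound 3 by methyl in place of hydrogen on an aromatic carbon; the new methyl sits next to the ring nitrogen, meta to the methyl group already present. Among the compounds with values here, no measured pair isolates this change. Because compound 3 stands only at < 10 nM, the step can only be estimated. A modest step toward weaker inhibition of growth, or none beyond the scatter, is expected. Compound 4 is estimated at 30 nM, within 5 nM to 300 nM, a step of an at least 3.0-fold higher number from compound 3 to compound 4 (0.47 log units; beyond the scatter).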

Compound 4, concentration for 50% growth inhibition: 13.2 nM
Compound 4: the middle estimate sits 2.3-fold (0.36 log units) above what was measured; low and high end bracket the measured number.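

In this assay, methyl in place of hydrogen on the core gives an at least 1.3-fold higher number from compound 3 to compound 4 (0.12 log units; that floor lies within the scatter), and the same change gives an at least 1.3-fold higher number from compound 1 to compound 4 (0.12 log units; that floor lies within the scatter), so a second core methyl is compatible with strong inhibition of growth. With both core methyls kept, chloro in place of methyl on an aromatic carbon gives a 1500-fold lower number from compound 2 to compound 4 (3.18 log units; beyond the scatter), which places the weakness of compound 2 with the methylphenyl aryl and not with the second core methyl.

The true size of the methyl step stays unresolved because the comparators sit at a limit: the limit of < 10 nM in this assay, at which 2 of the 4 values shown sit. As far as these compounds go, whether an ethyl, a methoxy or an amine at this core position would be accepted remains open.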